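Restoring an aromatic terminal ring in a cyclopropane amide series

The compounds below may be only part of what the source reports. "The series", "measured", "known", "first", "only" and "open" are said of these compounds alone.

The series is read in a functional assay for agonist activity at G protein-coupled receptor 88 (Homo sapiens), read by HTRF and cAMP accumulation; on this read-out higher numbers stand for an effect only at larger amounts of compound and lower numbers for an effect already at smaller amounts. Compound 1 `CC(C)C[C@H](N)CCN(C(=O)[C@@H]1C[C@H]1c1ccccc1)c1ccc(-c2ccccc2)cc1` gives 3 nM. Compound 2 `CC[C@H](C)[C@H](N)CN(C(=O)[C@@H]1C[C@H]1c1csc(C)n1)c1ccc(-c2ccccc2)cc1` gives 1500 nM. Compound 3 `CC(C)C[C@H](N)CN(C(=O)[C@@H]1C[C@H]1c1ccccc1)c1ccc(C2=CCCC2)cc1` gives 1200 nM, the second highest of the three numbers; its nearest neighbour is compound 2, within the scatter, and its furthest is compound 1, well beyond it. For the measured compounds named here, compound 3 and compound 1 differ in more than one place, so no single step between measured compounds can be read from the pair.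

Compound 4 `CC(C)C[C@H](N)CN(C(=O)[C@@H]1C[C@H]1c1ccccc1)c1ccc(-c2ccc(C#N)cc2)cc1` differs from compound 3 by 4-cyanophenyl in place of cyclopent-1-en-1-yl on an aromatic carbon, on an aromatic carbon of a six-membered aromatic ring of carbon only, para to a large group. Going by the values given here, only compound 1, the one compound carrying an aromatic group at that place, gives a low number, while compound 3 with a non-aromatic ring there gives a high one, so the step is expected to run toward a lower number and beyond the scatter, by a 10-fold lower number from compound 3 to compound 4 (1.00 log units; beyond the scatter). For compound 4 the expected value is 120 nM, within 20 nM to 800 nM; the estimate stays well above compound 1 since the two differ elsewhere as well.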

Compound 4, half-maximal effective concentration: 670 nM
Estimate against measurement, compound 4: 5.6-fold (0.75 log units) below, within the range that was stated.
By their numbers in this assay, from the lowest: compound 1; then compounds 4, 3 and 2 (each within the scatter of the next, the first and the last beyond it).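

In this assay, a 1.8-fold lower number from compound 3 to compound 4 (0.25 log units; within the scatter) stays within the scatter, so 4-cyanophenyl in place of cyclopent-1-en-1-yl, on an aromatic carbon para to a large group, gives no readable change. For the compounds shown here, this is the first single-place step, and it shows that an aromatic terminal ring carrying a nitrile does not by itself set compound 4 apart from compound 3. Nothing at hand bears on why these two compounds read alike.

Still open, from the compounds shown here alone, is whether the ring and the nitrile act separately at this place, which a plain phenyl or a 4-methoxyphenyl group on the otherwise unchanged structure of compound 4 would test. Also open, going by these compounds, is how this position responds when the amine-bearing chain is the longer one found in compound 1.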